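Naphthalenyl in Place of Trifluoromethylphenyl: Expected Cell Toxicity

The source may hold more compounds than are shown below. What is called first, only, known or untested is meant among the compounds shown, and "the series" means these compounds.

Compound 1 `c1ccc(-c2ccc3c(NCCCNCc4ccco4)ccnc3c2)cc1`: in an ADME assay on HepG2 cells (Homo sapiens) for cytotoxicity, read by luminescence, CellTiter-Glo and ATP content, with a stated time of 72 h (on this read-out lower numbers stand for an effect already at smaller amounts and higher numbers for an effect only at larger amounts of compound), compound 1 gives 5920 nM.
Compound 2 `COc1ccc(-c2ccc3c(NCCCNCc4ccco4)ccnc3c2)cc1`: in this assay compound 2 gives 6000 nM.
Compound 3 `FC(F)(F)c1ccc(-c2ccc3c(NCCCNCc4ccco4)ccnc3c2)cc1`: in this assay compound 3 gives 3470 nM.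

These three compounds share one core and differ only in a single group on a phenyl ring. Compound 3 shows the smallest number in name only: the step of a 1.7-fold lower number from compound 1 to compound 3 (0.23 log units; within the scatter) and the step of a 1.7-fold lower number from compound 2 to compound 3 (0.24 log units; within the scatter) both stay within the scatter, as does a 1.0-fold higher number from compound 1 to compound 2 (0.01 log units; within the scatter).

Compound 4 `c1coc(CNCCCNc2ccnc3cc(-c4cccc5ccccc45)ccc23)c1` differs from compound 3 in one place: naphthalen-1-yl in place of 4-(trifluoromethyl)phenyl on an aromatic carbon. For the measured compounds named here, no measured step exchanges the whole phenyl for another ring system, so the three steps bear on this change only loosely; each shows that varying this position hardly moved the read-out. Compound 4 is therefore expected to give 4000 nM, with a range from 1500 nM to 11000 nM. The expected step is a 1.2-fold higher number from compound 3 to compound 4 (0.06 log units; within the scatter), with no direction beyond the scatter expected.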

Compound 4, half-maximal effective concentration: 5600 nM
Compound 4: middle estimate off by 1.4-fold (0.15 log units), on the low side, and the stated range covers the measured number.
By their numbers in this assay, from the lowest: compounds 3, 4, 1 and 2 (each within the scatter of the next).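

Even the exchange of the whole phenyl for naphthalen-1-yl, with two six-membered aromatic rings in place of one, leaves this assay without a clear change: the steps are a 1.6-fold higher number from compound 3 to compound 4 (0.21 log units; within the scatter) and a 1.1-fold lower number from compound 2 to compound 4 (0.03 log units; within the scatter) and a 1.1-fold lower number from compound 1 to compound 4 (0.02 log units; within the scatter). So the flat picture at this position now extends beyond single groups on the phenyl to a larger ring system. No measurement here offers a reason for this. Still open, going by these compounds, is whether an amine or a carboxylic acid on the phenyl would move the number beyond the scatter.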